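Adding a Second Chloro Group: What to Expect

This account rests on a few compounds, and the source may have more. Where it says the series, first, only, none or still open, it means among the compounds named here.

Compound 1 `C[C@@H](NC(=O)Nc1ccccc1Cl)c1ccccc1` gives 103% in an ADME assay on the whole organism with Oryza sativa as the target, tested at 1 uM; a higher number here means a weaker effect of the compound at the concentration tested, a lower number a stronger effect.
Compound 2 `C[C@@H](NC(=O)Nc1ccccc1I)c1ccccc1` gives 100% in this assay.

Compound 1 holds the higher of the two numbers in this assay, but the gap to compound 2 is a number 3 percentage points lower from compound 1 to compound 2 (within the scatter), so the two cannot be told apart. Compound 3 `C[C@@H](NC(=O)Nc1cc(Cl)ccc1Cl)c1ccccc1` differs from compound 1 by chloro in place of hydrogen on an aromatic carbon. The single measured step swapped one halogen for another and stayed within the scatter; no measured step puts a group where a hydrogen was, so nothing shown bears directly on this change. The step expected in this assay is therefore a number 3 percentage points lower from compound 1 to compound 3 (within the scatter), nothing beyond the scatter. Compound 3 is estimated at 100%, between 85% and 110%.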

Compound 3, a percentage reported as activity, at one concentration (the size of the read-out at that concentration, not a potency): 100%
Beside the measured number, compound 3's estimate shows no gap at the digits printed; measured number inside the range.
By their numbers in this assay, from the lowest: compounds 2, 3 and 1 (each within the scatter of the next).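

Putting a chloro group in place of hydrogen, on the aromatic carbon para to a chloro group, gives a number 3 percentage points lower from compound 1 to compound 3 (within the scatter) in this assay on the core of compound 1. Among the steps shown, this is the only one that fills a place where a hydrogen stood, and here that change cannot be told from the scatter. Nothing measured on this change offers an explanation for the result.

Going by these compounds, whether an amine or a carboxylic acid at this same carbon would give a step beyond the scatter stays open. So does whether a chloro group on another carbon of this ring would behave alike.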